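Changing the Amide Aryl Group in an Interleukin-15 Binder

A few compounds are considered here, and "the series" means these few. Any claim that something is new, unique, unknown or untested is made for them only; others in the source may bear on it.

Compound 1, with the structure `Cn1c(Cc2nn(C)c(=O)c3ccccc23)nnc1SCCCCCCCC(=O)Nc1ccc(F)cc1F`, is one of three close relatives built on the same core. In an assay on isolated protein for binding affinity to interleukin-15 (Homo sapiens), read by surface plasmon resonance (on this read-out lower numbers stand for tighter binding and higher numbers for weaker binding), compound 1 has no reported result, recorded as "not determined" (no result reported), so it stands without a number of its own. Its nearest measured relative, compound 2 `Cn1c(Cc2nn(C)c(=O)c3ccccc23)nnc1SCCCCCCCC(=O)Nc1ccc(Br)cc1Br`, carries two bromine atoms on the amide aryl ring instead of two fluorine atoms; in this assay compound 2 gives 11600 nM, a weak binding affinity.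

Compound 3, with the structure `CC(C)COc1ccc(NC(=O)CCCCCCCSc2nnc(Cc3nn(C)c(=O)c4ccccc34)n2C)cc1`, is not yet measured. It differs from compound 1 in one place (4-(isobutoxy)phenyl in place of 2,4-difluorophenyl on an amide-type nitrogen); the 2,4-difluorophenyl group on the amide-type nitrogen is replaced by a 4-(isobutoxy)phenyl group.

Because compound 1 has no value, the size of the step to compound 3 cannot be anchored at its start. The expectation in this assay is a step of no more than modest size, in no confident direction, since the only measured anchor is a weak binder. Compound 3 is therefore expected to give about 10000 nM, within a range from 2000 nM to 50000 nM, because its relative compound 2 gives 11600 nM.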

Compound 3, dissociation constant: 25000 nM
The estimate for compound 3 lay 2.5-fold (0.40 log units) below the measured number; low and high end bracket the measured number.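

In this assay, putting 4-(isobutoxy)phenyl in place of 2,4-dibromophenyl on the amide-type nitrogen gives a 2.2-fold higher number from compound 2 to compound 3 (0.33 log units; beyond the scatter), so this change makes binding somewhat weaker. Among the compounds shown here, this is the first measured comparison at this position, and it shows that the number does respond to the aryl group on the amide-type nitrogen, though only modestly for two quite differently substituted rings. Both compounds remain weak binders, so neither aryl group stands out here, and nothing available explains the shift between them.

Going by these compounds, compound 1 has no number, so the step from it to compound 3 cannot be read, and how the 2,4-difluorophenyl group ranks against the other two aryl groups stays unknown. For the compounds shown here, with only two measured compounds, it also remains open whether a phenyl ring carrying an amine or a carboxylic acid, or a plain alkyl group in place of the ring on the amide-type nitrogen, would bring the number down, push it up or leave it where it is.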